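The source may hold more compounds than are shown below. What is called first, only, known or untested is meant among the compounds shown, and "the series" means these compounds.

Measured in a functional assay on 786-0 cells (Homo sapiens) for cytotoxicity, read by sulforhodamine B assay, with a stated time of 48 h, tested at 0.001 uM; on this read-out higher numbers stand for a weaker effect at the one concentration tested and lower numbers for a stronger effect:
- compound 1, `COc1cc(C)cc(-c2c(-c3ccnc(-c4ccc(N(C)C)cc4)c3)cnn2CC#N)c1`, gives 95%
- compound 2, `COc1cc(C)cc(-c2nn(CC#N)cc2-c2ccnc(-c3ccc(N(C)C)cc3)c2)c1`, gives 101%
- compound 3, `Cc1cc(O)cc(-c2nn(CC#N)cc2-c2ccnc(-c3ccc(Oc4ccccc4)cc3)c2)c1`, gives 98%

All three numbers sit close to the point at which the cells are unaffected at this single, very low concentration, and the number of compound 1 lies within the scatter of both compound 2 and compound 3. Going by the values given here, no pair of these three differs in only one place, so no single step can be read from them; their values simply show that each compound leaves the cells essentially untouched under these conditions.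

Compound 4, `COc1cc(C)cc(-c2c(-c3ccnc(-c4ccc(C(C)=O)cc4)c3)cnn2CC#N)c1`, is the next compound to be measured. Compared with compound 1 it carries acetyl in place of dimethylamino on an aromatic carbon. Among the compounds with values here, nothing among the measured compounds shows that any change at this end of the molecule moves the read-out beyond the scatter. The expected step of a number 3 percentage points higher from compound 1 to compound 4 (within the scatter) is therefore none beyond the scatter. Compound 4 is expected to give about 98%, most likely between 86% and 110%.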

Compound 4, a percentage reported as activity, at one concentration (the size of the read-out at that concentration, not a potency): 102%
Estimate against measurement, compound 4: 4 percentage points below; measured number inside the range.
By their numbers in this assay, from the lowest: compounds 1, 3, 2 and 4 (each within the scatter of the next).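

In this assay, exchanging the dimethylamino group for acetyl, para to a large group, gives a number 7 percentage points higher from compound 1 to compound 4 (within the scatter). Going by these compounds alone, this is the first pair here that differs in only one place, and it shows that, at this one very low concentration, the read-out does not separate 4-(dimethylamino)phenyl from 4-acetylphenyl. No available measurement bears on this result.

From the compounds shown here alone, it remains open whether a carboxylic acid, a primary amine or a longer carbon chain at this position would move the read-out beyond the scatter. Going by these compounds, it is also open whether compound 1 and compound 4 would separate at higher concentrations, and a reading at a single concentration gives no measure of potency.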